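Chloro in place of hydrogen on the aromatic ring

The source may hold more compounds than are shown below. What is called first, only, known or untested is meant among the compounds shown, and "the series" means these compounds.

Going by the values given here, compound 2 `CCC1(CCCCN2CCN(c3ccccc3)CC2)C(=O)Nc2ccccc21` holds the only number: in a functional assay on the whole organism (strain Wistar) with Rattus norvegicus as the target, with a stated time of 5 min (on this read-out higher numbers stand for an effect only at larger amounts of compound and lower numbers for an effect already at smaller amounts), compound 2 gives 10 mg/kg. Compound 1 `CCC1(CCCCN2CCN(c3cccc(OC)c3)CC2)C(=O)Nc2ccccc21` gives only a limit of this assay, > 20 mg/kg. Among the compounds with values here, the single measured step is an at least 2.0-fold lower number from compound 1 to compound 2 (0.30 log units; that floor lies within the scatter), whose floor rests on (the limit of > 20 mg/kg in this assay, at which 1 of the 2 values shown sits). Compound 3 `CCC1(CCCCN2CCN(c3cccc(Cl)c3)CC2)C(=O)Nc2ccccc21` differs from compound 2 by chloro in place of hydrogen on an aromatic carbon. On these data alone, only the methoxy-to-hydrogen step bears on this place, and there a group gave the larger number; chloro itself is untested, so compound 3 is expected to shift by a 1.5-fold higher number from compound 2 to compound 3 (0.18 log units; within the scatter) toward a higher number, with a fair chance of a limit. The estimate for compound 3 is 15 mg/kg, between 5 mg/kg and 40 mg/kg.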

Compound 3, minimum effective dose: > 20 mg/kg
Compound 3: a limit, no number (the forecaster's own chance of this, stated with the estimate: 40%); middle value at least 1.3-fold (0.12 log units) from the limit.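

In this assay, the change from phenyl to 3-chlorophenyl gives an at least 2.0-fold higher number from compound 2 to compound 3 (0.30 log units; that floor lies within the scatter). A second group at this place, chloro after methoxy, now ends at a limit, so compound 1 and compound 3 both carry limits rather than numbers, and the step between them cannot be read. Only compound 2, without a group here, gives a number, and the step to compound 3 shows only a floor: the limit of > 20 mg/kg in this assay, at which 2 of the 3 values shown sit.

On these data alone, what numbers lie behind the two limits stays open. Also open, as far as these compounds go, is whether an amine or a carboxylic acid at this place would give a number.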